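Compound 3 to compound 4: changing the aryl group

A few compounds are considered here, and "the series" means these few. Any claim that something is new, unique, unknown or untested is made for them only; others in the source may bear on it.

In an ADME assay on WI-38 cells (Homo sapiens) for cytotoxicity, read by MTT assay, with a stated time of 72 h (a lower number here means a stronger inhibitor, a higher number a weaker inhibitor), compound 1 `O=C(CCc1cccc2c1B(O)OC2)Nc1cccc(-c2cccc(F)c2)c1` gives 37000 nM, compound 2 `O=C(CCc1cccc2c1B(O)OC2)Nc1cccc(-c2ccc(F)cc2)c1` gives 4100 nM and compound 3 `O=C(CCc1cccc2c1B(O)OC2)Nc1cccc(-c2cccc(Cl)c2)c1` gives 58000 nM. Compound 3 belongs to the upper pair of numbers, whose members are not separated: a 1.6-fold higher number from compound 1 to compound 3 (0.20 log units; within the scatter). Its gap to the remaining compound is large: a 14-fold higher number from compound 2 to compound 3 (1.15 log units; beyond the scatter).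

Compound 4 `CSc1ccc(-c2cccc(NC(=O)CCc3cccc4c3B(O)OC4)c2)cc1` is not yet measured. The structural change is 4-(methylsulfanyl)phenyl in place of 3-chlorophenyl on an aromatic carbon. Going by the values given here, the closest precedent is 4-fluorophenyl in place of 3-fluorophenyl, a 9.0-fold lower number from compound 1 to compound 2 (0.96 log units; beyond the scatter). Among the compounds with values here, no measured compound carries 4-(methylsulfanyl)phenyl, so only part of that drop is expected to carry over. The expected move is a 4.8-fold lower number from compound 3 to compound 4 (0.68 log units; beyond the scatter), a modest step towards a lower number. For compound 4 the estimated value is 12000 nM, with an expected range of 3500 nM to 40000 nM.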

Compound 4, half-maximal inhibitory concentration: 3800 nM
Compound 4: the middle estimate sits 3.2-fold (0.50 log units) above what was measured; the range from low to high includes it.
By their numbers in this assay, from the lowest: compounds 4 and 2 (each within the scatter of the next); then compounds 1 and 3 (each within the scatter of the next).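

In this assay there is a 15-fold lower number from compound 3 to compound 4 (1.18 log units; beyond the scatter) and also a 9.7-fold lower number from compound 1 to compound 4 (0.99 log units; beyond the scatter) and so the low number is not confined to 4-fluorophenyl. Going by these compounds alone, with a 1.1-fold lower number from compound 2 to compound 4 (0.03 log units; within the scatter) as the remaining step, methylsulfanyl and fluoro are not separated on this ring, and across these four compounds 4-fluorophenyl and 4-(methylsulfanyl)phenyl sit low while 3-fluorophenyl and 3-chlorophenyl sit high, with no compound going against this. No evidence is at hand that accounts for this split.

Open, on these data alone, is whether 3-(methylsulfanyl)phenyl would join compound 1 and compound 3, which would separate the group from its place on the ring. Also open, as far as these compounds go, is whether 4-aminophenyl or 4-carboxyphenyl would stay with compound 2 and compound 4.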